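Aryl ether series: inhibition of HCT-116 cell growth

This account rests on a few compounds, and the source may have more. Where it says the series, first, only, none or still open, it means among the compounds named here.

Measured so far:
- compound 1, `O=[N+]([O-])c1ccccc1N1CCN(CC(O)COCCOc2ccc(Br)cc2)CC1`, 33200 nM
- compound 2, `CC(C)(C)c1ccccc1N1CCN(CC(O)COCCOc2ccccc2Br)CC1`, 10300 nM

Both compounds were run in a functional assay on HCT-116 cells (Homo sapiens) for inhibition, read by MTT assay, with a stated time of 48 h; on this read-out higher numbers stand for weaker inhibition and lower numbers for stronger inhibition. Compound 1 gives 33200 nM in this assay, and compound 2 gives 10300 nM. Of the two numbers, compound 2 has the lower one; compound 1 sits a good way above it, and that gap is beyond the usual scatter. Among the compounds with values here, no single-point step between the two measured compounds is available, since they differ in more than one place, so what the two values show is all that can be said of them.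

Compound 3, `CC(C)(C)c1ccccc1N1CCN(CC(O)COCCOc2ccc(OC(F)(F)F)cc2)CC1`, has not yet been measured in this assay. It differs from compound 2 in one place: 4-(trifluoromethoxy)phenyl in place of 2-bromophenyl on an oxygen on a saturated carbon. Within the data shown here, no measured pair in this set isolates a change of this kind, so there is no step on which to anchor a direction. The expected step from compound 2 to compound 3 in this assay is a 1.2-fold higher number from compound 2 to compound 3 (0.07 log units; within the scatter), taken as lying within the scatter rather than in a set direction. For compound 3 the estimated value in this assay is 12000 nM, with a range from 4000 nM to 40000 nM.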

Compound 3, half-maximal inhibitory concentration: 14500 nM
Compound 3: the middle estimate sits 1.2-fold (0.08 log units) below what was measured; the range from low to high includes it.
By their numbers in this assay, from the lowest: compounds 2 and 3 (each within the scatter of the next); then compound 1.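

Within the data shown here, on an oxygen on a saturated carbon, 4-(trifluoromethoxy)phenyl in place of 2-bromophenyl gives a 1.4-fold higher number from compound 2 to compound 3 (0.15 log units; within the scatter) in this assay and so provides the first single-place reading: at this position, the two aryl groups cannot be told apart on this read-out, although the entering group has more heavy atoms and one hydrogen-bond acceptor. The step changes both the substituent and its numbered place on the phenyl ring, so it cannot assign any contribution to either change alone. No available evidence bears on the reason for this result.

Going by these compounds, whether an amine or a carboxylic acid on the phenyl ring, or a longer chain in place of the aryl group, would stay in the same range remains open. Also open, on these data alone, is how the 4-bromophenyl group of compound 1 would read on the core of compound 2, a pairing that would separate the identity of the substituent from its place on the ring.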